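Two weak compounds and a methoxy added to the core

The source may report more compounds than this note shows. Statements on the series, on what has been measured and on what is new or still open speak of the compounds shown alone.

The account concerns an assay for binding affinity to Adrenergic receptor alpha-1 (Rattus norvegicus) (a higher number here means a weaker inhibitor, a lower number a stronger inhibitor), and three compounds that share a saturated bicyclic core linked through a carbon chain to a cyclohexyl-bearing piperazine. Compound 1, `COc1ccc2c(c1)C(CCCN1CCN(C3CCCCC3)CC1)CCC2`, carries a methoxy group and a shorter chain. In this assay compound 1 reaches only the limit > 7500 nM, not a number. Compound 2, `c1ccc2c(c1)CCCC2CCCCCN1CCN(C2CCCCC2)CC1`, has the longer chain and no methoxy group. In this assay compound 2 likewise gives only the limit > 7500 nM, so that both values shown sit at the limit of > 7500 nM in this assay, at which 2 of the 2 values shown sit, and compound 2 stands nowhere in particular among them. Compound 3, `COc1cccc2c1CCCC2CCCCCN1CCN(C2CCCCC2)CC1`, differs from compound 2 by methoxy in place of hydrogen on an aromatic carbon, a methoxy in place of hydrogen on an aromatic carbon. Going by the values given here, no measured step of this kind is available. Since compound 2 and compound 1 both sit at the limit, the step is expected to be a step that the limit leaves unreadable from compound 2 to compound 3, none beyond the scatter. Compound 3 is therefore estimated at 9000 nM, between 4000 nM and 25000 nM.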

Compound 3, inhibition constant: > 7500 nM
Compound 3 was reported as a limit; the forecaster's own chance of this, stated with the estimate: 70%; the middle value lies beyond the limit too.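

Compound 3, like compound 2, is reported in this assay only as a limit, so no step can be read between the two: the limit of > 7500 nM in this assay, at which 3 of the 3 values shown sit.

The compounds shown leave open the actual affinity of compound 1, compound 2 and compound 3, and whether methoxy in place of hydrogen on an aromatic carbon changes it at all.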